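Halogen exchange on a shared core: cytotoxicity working notes

The source may report more compounds than this note shows. Statements on the series, on what has been measured and on what is new or still open speak of the compounds shown alone.

Measured so far:
compound 1 `Nc1ncc(Br)c2c1ncn2[C@@H]1C[C@H](O)[C@@H](O)[C@H]1O` — > 273000 nM
compound 2 `Nc1ncc(I)c2c1ncn2[C@@H]1C[C@H](O)[C@@H](O)[C@H]1O` — > 242000 nM

In an ADME assay on MDCK cells (Canis lupus familiaris) for cytotoxicity (a higher number here means that more compound is tolerated, a lower number that less compound is tolerated), compound 1 gives > 273000 nM, which is a limit of the assay and not a number. In this assay compound 2 gives > 242000 nM, likewise a limit. Within the data shown here, the only measured step, a step that the two limits leave unreadable from compound 1 to compound 2, is therefore unreadable in size and direction. Among the measured compounds shown here, compound 2 stands only at a limit in this assay, and the one further value shown is a limit as well, so no ranking of compound 1 against compound 2 is possible.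

Compound 3 `Nc1ncc(Cl)c2c1ncn2[C@@H]1C[C@H](O)[C@@H](O)[C@H]1O` differs from compound 2 by chloro in place of iodo on an aromatic carbon. For the measured compounds named here, the sole step that bears on this change is the bromo-to-iodo step above, and its two ends sit at the limit of > 273000 nM in this assay, at which 1 of the 2 values shown sits, and (the limit of > 242000 nM in this assay, at which 1 of the 2 values shown sits); it gives no readable size. With only limits to go on, compound 3 is expected to sit at a limit as well, and the expected step that the limit leaves unreadable from compound 2 to compound 3 is none beyond the scatter. Compound 3 is estimated at 260000 nM in this assay, within 120000 nM to 600000 nM.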

Compound 3, half-maximal cytotoxic concentration: > 311000 nM
Compound 3 ended at the assay's limit; the forecaster's own chance of this, stated with the estimate: 85%; at least 1.1-fold (0.07 log units) between middle value and limit.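

In this assay, among these compounds, compound 1, compound 2 and compound 3 all stand at limits of the assay, so no step among them can be read in size or direction. The compounds shown leave open whether chloro, bromo and iodo on the shared core differ at all in the concentration tolerated.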